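A few compounds are considered here, and "the series" means these few. Any claim that something is new, unique, unknown or untested is made for them only; others in the source may bear on it.

Measured compounds:
compound 1 `C[C@@H]1N[C@H](C(=O)N2CCC[C@H]2C#N)C[C@@H]1C(=O)N1CCC1` — 94%
compound 2 `N#C[C@@H]1CCCN1C(=O)[C@@H]1C[C@H](C(=O)N2CCCCCC2)CN1` — 68%
compound 3 `N#C[C@@H]1CCCN1C(=O)[C@@H]1C[C@H](CCO)CN1` — 64%

In an assay on the whole organism (plasma, strain Sprague-Dawley) for inhibition of Dipeptidyl peptidase 4 (Rattus norvegicus), with a stated time of 6 h, at a dose of 1 mg/kg by the oral route (a lower number here means less inhibition, a higher number more inhibition at the dose given (going by the name of the read-out)), compound 3 gives 64%, the smallest of the three numbers. Compound 2, with 68%, sits within the usual scatter of compound 3, so the two cannot be told apart. Compound 1, with 94%, stands well beyond the scatter above compound 3.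

The step to the unmeasured compound 4 `N#C[C@@H]1CCCN1C(=O)[C@@H]1C[C@H](C(=O)N2CCC2)CN1` changes one place on the shared core: (azetidin-1-yl)carbonyl in place of 2-hydroxyethyl on a saturated ring carbon. Among the measured compounds shown here, no measured pair in this set differs in exactly this way, so no measured step can be read across directly. Still, compound 4 is expected to move upward in this assay, with a step of a number 16 percentage points higher from compound 3 to compound 4 (beyond the scatter) that goes beyond the scatter, because compound 2 gives 68% and compound 1 gives 94%, both amide-bearing compounds at or above the number of compound 3. Compound 4 is therefore estimated at 80%, with a plausible range from 62% to 94%.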

Compound 4, a percentage reported as inhibition, in the whole organism at one dose (the size of the read-out at that dose, not a potency): 77%
Compound 4: middle estimate off by 3 percentage points, on the high side, and the stated range covers the measured number.
By their numbers in this assay, from the lowest: compounds 3, 2 and 4 (each within the scatter of the next, the first and the last beyond it); then compound 1.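

In this assay, the change at the saturated ring carbon two ring bonds from the ring nitrogen can now be read directly: (azetidin-1-yl)carbonyl in place of 2-hydroxyethyl gives a number 13 percentage points higher from compound 3 to compound 4 (beyond the scatter). With the carbonyl kept, azetidin-1-yl in place of azepan-1-yl gives a number 9 percentage points higher from compound 2 to compound 4 (within the scatter), so these two groups cannot be told apart here, whereas hydrogen in place of the methyl on a saturated ring carbon gives a number 17 percentage points lower from compound 1 to compound 4 (beyond the scatter). Nothing measured here accounts for any of these steps.

As far as these compounds go, whether a carboxylic acid or a primary amine on the ring carbon two ring bonds from the ring nitrogen would read like (azetidin-1-yl)carbonyl remains open. Also open, from the compounds shown here alone, is whether the methyl step would hold with azepan-1-yl on the carbonyl carbon.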